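The source may hold more compounds than are shown below. What is called first, only, known or untested is meant among the compounds shown, and "the series" means these compounds.

Measured so far in a functional assay on MCF7 cells (Homo sapiens) for inhibition; on this read-out lower numbers stand for stronger inhibition and higher numbers for weaker inhibition:
- compound 1 `Oc1ccc(-c2nc3cc(F)ccc3s2)cc1`: 400 nM
- compound 2 `COc1ccc2nc(-c3ccc(O)cc3)sc2c1`: 45800 nM
- compound 3 `COc1ccc(-c2nc3cc(F)ccc3s2)cc1F`: 870 nM

Compound 3 holds the middle place of the three numbers. At 870 nM, compound 3 lies closest to compound 1 at 400 nM, and that gap is beyond the scatter, with compound 1 the stronger inhibitor. Compound 2 stands much further off at 45800 nM, also beyond the scatter, as the weakest of the three.

The next compound is compound 4 `COc1ccc(-c2nc3cc(F)ccc3s2)cc1Br`, which has bromo in place of fluoro on an aromatic carbon, ortho to a methoxy group and meta to a large group: bromo in place of fluoro on an aromatic carbon. Among the compounds with values here, no two measured compounds differ in one place only, so the series offers no direct precedent for this exchange, and the expectation rests on the value of compound 3 alone. No step beyond the scatter is expected in this assay, and no direction is favoured with any confidence. The estimated 1.1-fold lower number from compound 3 to compound 4 (0.04 log units; within the scatter) is therefore small. The wide spread of values, with compound 2 at 45800 nM, argues for a broad range. For compound 4 the estimated value is 800 nM, with an expected range from 250 nM to 3000 nM.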

Compound 4, half-maximal inhibitory concentration: 850 nM
Compound 4: middle estimate off by 1.1-fold (0.03 log units), on the low side, within the range that was stated.
By their numbers in this assay, from the lowest: compound 1; then compounds 4 and 3 (each within the scatter of the next); then compound 2.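

In this assay, within the data shown here, bromo in place of fluoro on an aromatic carbon, ortho to a methoxy group and meta to a large group, gives a 1.0-fold lower number from compound 3 to compound 4 (0.01 log units; within the scatter), and this is the first step that changes one place only. At this position, the read-out does not separate the two groups, so the exchange of fluoro for bromo gives no measurable gain or loss here and compound 3 and compound 4 can be treated as equivalent in this assay. Nothing measured in the series speaks to why this exchange leaves the number within the scatter.

On these data alone, the step covers only these two groups at this one position, so it remains open whether a nitrile, an amine or a carboxylic acid at the same carbon would leave the number as unchanged as bromo does. Also open, as far as these compounds go, is how much the methoxy group itself contributes while the rest of compound 4 stays fixed, which a single-place exchange to an ethoxy group or a longer chain would show.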